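A few compounds are considered here, and "the series" means these few. Any claim that something is new, unique, unknown or untested is made for them only; others in the source may bear on it.

Two members of this series have been run in a functional assay on HepG2 cells (Homo sapiens) for cytotoxicity, read by MTT assay, with a stated time of 48 h; a higher number here means a weaker inhibitor, a lower number a stronger inhibitor. For compound 1 `CCCCCCCCCCCCNC(=O)[C@@H](NC(=O)/C=C/c1ccccc1)[C@@H](C)O` the assay reports only a limit, > 200000 nM. For compound 2 `C/C=C/C=C/C(=O)N[C@H](C(=O)NCCCCCCCCCCCC)[C@@H](C)O` the assay again reports only a limit, > 400000 nM. Going by the values given here, the single change between them, prop-1-en-1-yl in place of phenyl on a double-bonded chain carbon bound to a double-bonded chain carbon, gives a step that the two limits leave unreadable from compound 1 to compound 2; compound 1 sits at the limit of > 200000 nM in this assay, at which 1 of the 2 values shown sits, and compound 2 at the limit of > 400000 nM in this assay, at which 1 of the 2 values shown sits, so the step has no readable size. Compound 2 therefore stands only as a limit, the looser of the two shown, with no number to anchor it.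

Compound 3 `CCCCCCCCCCCCNC(=O)[C@@H](NS(=O)(=O)c1ccc(C)cc1)[C@@H](C)O` differs from compound 2 by (4-methylphenyl)sulfonyl in place of (penta-1,3-dien-1-yl)carbonyl on an amine nitrogen. Among the compounds with values here, no measured step bears on an exchange of this kind, and the only step in hand, a step that the two limits leave unreadable from compound 1 to compound 2, is itself unreadable. With both measured compounds at limits, nothing points to a readable shift in either direction. For compound 3 the expected step is an at least 1.3-fold lower number from compound 2 to compound 3 (0.12 log units; that floor lies within the scatter), nothing beyond the scatter. Compound 3 is estimated at 300000 nM, within 100000 nM to 1000000 nM, and most probably reported as a limit only.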

Compound 3, half-maximal inhibitory concentration: 25800 nM
Estimate against measurement, compound 3: 12-fold (1.07 log units) above; measured number outside the range, below it.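

In this assay, the amine nitrogen proves able to carry a change of readable size: (4-methylphenyl)sulfonyl in place of (penta-1,3-dien-1-yl)carbonyl gives an at least 15-fold lower number from compound 2 to compound 3 (1.19 log units; beyond the scatter), and (4-methylphenyl)sulfonyl in place of (2-phenylethenyl)carbonyl gives an at least 7.7-fold lower number from compound 1 to compound 3 (0.88 log units; beyond the scatter). The step between the two carbonyl compounds cannot be read, so the two carbonyl groups cannot be ranked against each other, whereas compound 3, with the sulfonyl group, is the only one of the three to give a number rather than a limit. The larger step is only a floor because compound 2 stands at a limit: the limit of > 400000 nM in this assay, at which 1 of the 3 values shown sits.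

The compounds shown do not separate the contribution of the sulfonyl link from that of the 4-methylphenyl ring, since both enter together; a methanesulfonyl group or a 4-methylbenzoyl group on the same amine nitrogen would pull the two apart. From the compounds shown here alone, whether the number in this assay depends on the dodecyl chain of the shared core also stays open, and a compound 3 analogue with a shorter chain would address it.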